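Adding one carbon to the chain of compound 3

This account rests on a few compounds, and the source may have more. Where it says the series, first, only, none or still open, it means among the compounds named here.

Three measured compounds share the same core and differ only in the branched chain that sits on a nitrogen on the aromatic ring. In an assay on isolated protein for inhibition of Amine oxidase [flavin-containing] B (Homo sapiens), read by fluorescence, with a stated time of 20 min (a lower number here means a stronger inhibitor, a higher number a weaker inhibitor), compound 1 `CC/C(C)=N\Nc1nc(-c2cccc([N+](=O)[O-])c2)cs1` gives 351 nM. Compound 2 `CCC(CC)=NNc1nc(-c2cccc([N+](=O)[O-])c2)cs1` gives 53 nM in this assay, and compound 3 `CCCC/C(C)=N\Nc1nc(-c2cccc([N+](=O)[O-])c2)cs1` gives 118 nM. Among these three numbers compound 3 stands second highest: the step of a 2.2-fold higher number from compound 2 to compound 3 (0.35 log units; beyond the scatter) separates it from its nearest neighbour, and the step of a 3.0-fold lower number from compound 1 to compound 3 (0.47 log units; beyond the scatter) from the furthest one.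

Compound 4 `CCCC/C(CC)=N\Nc1nc(-c2cccc([N+](=O)[O-])c2)cs1` has not yet been measured in this assay. It differs from compound 3 by methyl in place of hydrogen on a saturated chain carbon bound to a carbon with a double bond to nitrogen; cut one bond further out, the same difference reads methyl to ethyl. Among the measured compounds shown here, the closest precedent is the step of a 6.6-fold lower number from compound 1 to compound 2 (0.82 log units; beyond the scatter), which also enlarged the group on the nitrogen on the aromatic ring by a single carbon and moved the number clearly downward. The step of a 3.0-fold lower number from compound 1 to compound 3 (0.47 log units; beyond the scatter) points the same way, while the step of a 2.2-fold higher number from compound 2 to compound 3 (0.35 log units; beyond the scatter) shows that a longer chain does not always help. On balance a moderate drop beyond the scatter seems the likelier outcome. Compound 4 is therefore expected to give about 50 nM, within a range from 20 nM to 150 nM. Such an estimate means a step of a 2.4-fold lower number from compound 3 to compound 4 (0.37 log units; beyond the scatter).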

Compound 4, half-maximal inhibitory concentration: 182 nM
Compound 4: middle estimate off by 3.6-fold (0.56 log units), on the low side; the whole stated range lies below it.
By their numbers in this assay, from the lowest: compound 2; then compounds 3, 4 and 1 (each within the scatter of the next, the first and the last beyond it).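

In this assay, the methyl to ethyl difference gives a 1.5-fold higher number from compound 3 to compound 4 (0.19 log units; within the scatter), so on the chain of compound 3 this added carbon produces no readable change, unlike the same difference in a 6.6-fold lower number from compound 1 to compound 2 (0.82 log units; beyond the scatter). Ethyl in place of hydrogen on a saturated chain carbon, two bonds along the chain from a carbon with a double bond to nitrogen, gives a 3.4-fold higher number from compound 2 to compound 4 (0.54 log units; beyond the scatter), and this is the first time that lengthening has been seen on a compound that already carries two ethyl-length arms. The effect of this lengthening therefore depends on the starting compound, and it can even change direction: the same change on two cores in this assay, a 3.0-fold lower number (0.47 log units; beyond the scatter) from compound 1 to compound 3 and a 3.4-fold higher number (0.54 log units; beyond the scatter) from compound 2 to compound 4, 10-fold (1.01 log units) apart, beyond the scatter of two such steps.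

The compounds shown leave open what a propyl group in place of the ethyl of compound 4 would do, and whether a ring joining the two chains would behave like either open-chain pair. They also leave open whether an amine or a hydroxyl group at the end of the longer chain would follow the same reversal.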